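A few compounds are considered here, and "the series" means these few. Any claim that something is new, unique, unknown or untested is made for them only; others in the source may bear on it.

Measured so far:
compound 1, `O=C(CN1CCN(c2cc3c(cc2F)c(=O)c(C(=O)O)cn3C2CC2)CC1)Nc1ccc(C(=O)/C=C/c2cccc(Cl)c2)cc1` — 34.4 ug/mL
compound 2, `O=C(CN1CCN(c2cc3c(cc2F)c(=O)c(C(=O)O)cn3C2CC2)CC1)Nc1ccc(C(=O)/C=C/c2ccc(Cl)cc2)cc1` — 2.77 ug/mL

Both numbers come from a physicochemical assay for solubility, at pH 6.9; on this read-out higher numbers stand for higher solubility and lower numbers for lower solubility. Compound 1 stands highest of the two; the gap is a 12-fold lower number from compound 1 to compound 2 (1.09 log units; beyond the scatter). Compound 3, `O=C(CN1CCN(c2cc3c(cc2F)c(=O)c(C(=O)O)cn3C2CC2)CC1)Nc1ccc(C(=O)/C=C/c2cccc([N+](=O)[O-])c2)cc1`, has not yet been measured. It differs from compound 1 in one place: nitro in place of chloro on an aromatic carbon. Within the data shown here, the single measured step, a 12-fold lower number from compound 1 to compound 2 (1.09 log units; beyond the scatter), concerns 4-chlorophenyl in place of 3-chlorophenyl and keeps the chloro, so no measured step bears directly on a nitro entering. With nothing to anchor it, the expected change is small, a 1.2-fold higher number from compound 1 to compound 3 (0.07 log units; within the scatter), and the range is wide. Compound 3 is estimated to give 40 ug/mL, between 10 ug/mL and 150 ug/mL.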

Compound 3, solubility: 30.7 ug/mL
The estimate for compound 3 lay 1.3-fold (0.11 log units) above the measured number; the measured number falls inside the stated range.
By their numbers in this assay, from the lowest: compound 2; then compounds 3 and 1 (each within the scatter of the next).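

In this assay, exchanging chloro for nitro on this aromatic carbon, 3-chlorophenyl to 3-nitrophenyl, leaves the number within the scatter (a 1.1-fold lower number from compound 1 to compound 3 (0.05 log units; within the scatter)). The 3-nitrophenyl group also stands clear of 4-chlorophenyl (an 11-fold higher number from compound 2 to compound 3 (1.04 log units; beyond the scatter)), so compounds 1 and 3 sit together while compound 2 lies apart. No measurement here explains this gap. As far as these compounds go, whether a 4-nitrophenyl group would drop as 4-chlorophenyl did remains open, as does the effect of a methoxy group or a primary amine on the same aromatic carbon.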